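A five-membered ring exchanged on compound 2

The source may report more compounds than this note shows. Statements on the series, on what has been measured and on what is new or still open speak of the compounds shown alone.

Compound 1 `CC(C)C(Cc1ncc[nH]1)c1ccc(-c2ccc3cccc(F)c3c2)[nH]c1=O` gives < 0.0667 h in an ADME assay on microsomes from liver (Rattus norvegicus) for metabolic stability (a higher number here means that the compound lasts longer, a lower number that the compound disappears faster), which is a limit of the assay and not a number. Among the measured compounds shown here, compound 2 `CC(C)C(c1cnc(N)s1)c1ccc(-c2ccc3cccc(F)c3c2)[nH]c1=O` gives 0.0983 h in this assay, the only actual number so far. Compound 3 `CC(C)C(c1noc(=O)[nH]1)c1ccc(-c2ccc3cccc(F)c3c2)[nH]c1=O` has not yet been measured. It differs from compound 2 by a group of 6 heavy atoms (2 carbon, 2 nitrogen, 2 oxygen; one five-membered aromatic ring with 3 hetero atoms) in place of a group of 6 heavy atoms (3 carbon, 2 nitrogen, 1 sulfur; one five-membered aromatic ring with 2 hetero atoms), on a saturated chain carbon bound to an aromatic carbon and a saturated chain carbon: the 2-amino-1,3-thiazol-5-yl group leaves and a five-membered aromatic ring with 3 hetero atoms enters, on a saturated chain carbon bound to an aromatic carbon and a saturated chain carbon. For the measured compounds named here, one measured step bears on this place, an at least 1.4-fold higher number from compound 1 to compound 2 (0.16 log units; that floor lies within the scatter). That step rests on the limit of < 0.0667 h in this assay, at which 1 of the 2 values shown sits, and involves a different pair of groups, so it is only a weak guide. A small step in this assay is therefore expected, within the scatter and leaning slightly upward. The expected change is a 1.2-fold higher number from compound 2 to compound 3 (0.09 log units; within the scatter). For compound 3 the estimate is 0.12 h, with an expected range of 0.06 h to 0.3 h.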

Compound 3, half-life: > 3 h
Compound 3: only a limit was reported (the forecaster's own chance of this, stated with the estimate: 20%); at least 25-fold (1.39 log units) between middle value and limit.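

In this assay, the group on the saturated chain carbon bound to an aromatic carbon and a saturated chain carbon proves able to move the half-life far more than the first pair could show, with an at least 30-fold higher number from compound 2 to compound 3 (1.48 log units; beyond the scatter) and an at least 44-fold higher number from compound 1 to compound 3 (1.65 log units; beyond the scatter). The 2-amino-1,3-thiazol-5-yl group and the ring that replaces it have the same count of heavy atoms, hydrogen-bond donors and hydrogen-bond acceptors, and neither carries a net charge, so a large step here occurs with those counts unchanged. Compound 3 gives a limit of the assay and not a number, so the full size of both steps stays unknown: the limit of > 3 h in this assay, at which 1 of the 3 values shown sits.

The compounds shown do not separate the part played by the ring atoms from that of the double bond outside the aromatic ring, which only the entering group has. From the compounds shown here alone, whether a carboxylic acid or a simple amine on the same chain carbon would also last longer in this assay remains open, as does whether the same exchange would hold on another core.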